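From 4-(trifluoromethoxy)phenyl to 3-chlorophenyl in growth inhibition

This account rests on a few compounds, and the source may have more. Where it says the series, first, only, none or still open, it means among the compounds named here.

Of the compounds shown here, two have been measured in a functional assay on HOP-62 cells (Homo sapiens) for inhibition, read by sulforhodamine B assay; a lower number here means a stronger inhibitor of growth, a higher number a weaker inhibitor of growth. Compound 1 (`Clc1cccc(-c2ccc(-c3ccc(-c4nc5ccccc5[nH]4)cc3)cc2)c1`) gives 100000 nM, while compound 2 (`Oc1cccc2[nH]c(-c3ccc(-c4ccc(-c5ccc(OC(F)(F)F)cc5)cc4)cc3)nc12`) gives 2270 nM. Compound 2 therefore holds the lower of the two numbers, and the gap between them lies beyond the usual scatter of repeated measurements.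

The next structure is compound 3 (`Oc1cccc2[nH]c(-c3ccc(-c4ccc(-c5cccc(Cl)c5)cc4)cc3)nc12`), which keeps the core of compound 2 but carries 3-chlorophenyl in place of 4-(trifluoromethoxy)phenyl on an aromatic carbon.

Within the data shown here, no measured pair isolates this exchange, so its effect in this assay can only be judged loosely. Among the measured compounds shown here, the sole measured compound bearing 3-chlorophenyl is compound 1 at 100000 nM, but its core differs from that of compound 3, so it offers only a weak warning that the number may rise. A modest move toward weaker growth inhibition is therefore expected, with an estimated 2.2-fold higher number from compound 2 to compound 3 (0.34 log units; beyond the scatter).

For compound 3 the estimate is 5000 nM, with an expected range of 1500 nM to 25000 nM.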

Compound 3, concentration for 50% growth inhibition: 2260 nM
Compound 3: the middle estimate sits 2.2-fold (0.34 log units) above what was measured; low and high end bracket the measured number.
By their numbers in this assay, from the lowest: compounds 3 and 2 (each within the scatter of the next); then compound 1.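

In this assay, exchanging 4-(trifluoromethoxy)phenyl for 3-chlorophenyl on this aromatic carbon, para to a large group, gives a 1.0-fold lower number from compound 2 to compound 3 (0.00 log units; within the scatter), so the two compounds cannot be told apart despite the different groups and their different sizes. Compound 3 also supplies the first pair that isolates hydroxy in place of hydrogen on an aromatic carbon, and this change gives a 44-fold lower number from compound 1 to compound 3 (1.65 log units; beyond the scatter), a large step, so among these compounds the large difference goes with the hydroxy exchange and not with the exchange of the outer aromatic group. Nothing available gives a cause for either step.

The compounds shown leave open whether the hydroxy step would be of similar size with 4-(trifluoromethoxy)phenyl in place of 3-chlorophenyl, and whether a methoxy group or an amine in place of the hydroxy would give a similar number. They also leave open how far this position remains indifferent to its substituent, for instance whether an unsubstituted phenyl or a phenyl carrying a carboxylic acid would stay within the scatter of compound 3.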